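From compound 1 to compound 4 under a shared limit

The source may hold more compounds than are shown below. What is called first, only, known or untested is meant among the compounds shown, and "the series" means these compounds.

Compound 1 `COC1=C(C)C(=O)/C(=C(O)/C=C/c2cccc(OC)c2)C(=O)C1(C)C`: < 4 ug/mL (a limit)
Compound 2 `COC1=C(C)C(=O)/C(=C(O)/C=C/c2ccccc2OC)C(=O)C1(C)C`: < 4 ug/mL (a limit)
Compound 3 `COC1=C(C)C(=O)/C(=C(O)/C=C/c2ccc(F)cc2)C(=O)C1(C)C`: < 4 ug/mL (a limit)

In a functional assay on HUVEC cells (Homo sapiens) (on this read-out higher numbers stand for an effect only at larger amounts of compound and lower numbers for an effect already at smaller amounts), compound 1 has only a limit, < 4 ug/mL, and no exact number. The picture around it is the limit of < 4 ug/mL in this assay, at which 3 of the 3 values shown sit, so its place among the measured compounds cannot be read.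

Compound 4 `COC1=C(C)C(=O)/C(=C(O)/C=C/c2ccc(C)cc2)C(=O)C1(C)C` has not yet been measured and differs from compound 1 in one place: 4-methylphenyl in place of 3-methoxyphenyl on a double-bonded chain carbon bound to a double-bonded chain carbon. The 4-methylphenyl group thus takes the place of the 3-methoxyphenyl group on the same chain carbon, while the shared core stays unchanged.

Among the measured compounds shown here, three measured steps bear on this change, each exchanging one aryl group for another. They are a step that the two limits leave unreadable from compound 1 to compound 2, a step that the two limits leave unreadable from compound 1 to compound 3 and a step that the two limits leave unreadable from compound 2 to compound 3. None of them has a readable size, so they give no direction for the new change. They show only that all three aryl variants reach the same limit in this assay. On that basis, no step beyond the scatter is expected, and the result may well be reported as a limit again.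

The expected step is a step that the limit leaves unreadable from compound 1 to compound 4.

For compound 4 the estimated value is 2 ug/mL.

The expected range for compound 4 runs from 0.7 ug/mL to 5 ug/mL.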

Compound 4, concentration for half-maximal effect: < 4 ug/mL
Compound 4 ended at the assay's limit (the forecaster's own chance of this, stated with the estimate: 85%); the middle value is on the limit's open side.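

In this assay compound 4 gives < 4 ug/mL, a limit, so none of its steps to compound 1, compound 2 or compound 3 can be read: the limit of < 4 ug/mL in this assay, at which 4 of the 4 values shown sit.

The compounds shown leave open whether compound 1, compound 2, compound 3 and compound 4 differ at all in this assay, and by how much.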